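From Compound 2 to Its Methylsulfanyl Relative

The source may hold more compounds than are shown below. What is called first, only, known or untested is meant among the compounds shown, and "the series" means these compounds.

In a functional assay on HCT-116 cells (Homo sapiens) for antiproliferative activity, read by MTT assay, with a stated time of 72 h (on this read-out higher numbers stand for weaker inhibition and lower numbers for stronger inhibition), compound 1 (`O=C(CCc1cccc2c1B(O)OC2)Nc1ccc(Br)cc1`) gives 46000 nM and compound 2 (`O=C(CCc1cccc2c1B(O)OC2)Nc1cccc(-c2ccccc2)c1`) gives 890 nM as the lower, and so stronger, of the two numbers. Compound 3 (`CSc1cccc(-c2cccc(NC(=O)CCc3cccc4c3B(O)OC4)c2)c1`) differs from compound 2 by a single swap of phenyl to 3-(methylsulfanyl)phenyl (methylsulfanyl in place of hydrogen on an aromatic carbon). Among the measured compounds shown here, no measured compound carries this group, so the forecast rests on little evidence. In this assay the expected move is a 1.5-fold lower number from compound 2 to compound 3 (0.17 log units; within the scatter) and thus nothing beyond the scatter, with a slight lean towards stronger inhibition. For compound 3 the estimated value is 600 nM (expected range 150 nM to 2500 nM).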

Compound 3, half-maximal inhibitory concentration: 110 nM
Beside the measured number, compound 3's estimate is 5.5-fold (0.74 log units) above it, and the stated range ends above it.
By their numbers in this assay, from the lowest: compound 3; then compound 2; then compound 1.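

In this assay the swap of phenyl to 3-(methylsulfanyl)phenyl gives an 8.1-fold lower number from compound 2 to compound 3 (0.91 log units; beyond the scatter) and so shows that this aromatic carbon can take a small added group, with stronger inhibition beyond the usual scatter. The earlier compounds shown here carried no substituent on this ring and could not show this. No supporting measurement explains the gain.

Going by these compounds, whether sulfur is needed stays open, since methoxy, with oxygen in its place, would test that. A longer chain such as ethylsulfanyl, or an amine on this same carbon, would show how much other groups change the number.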